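A Mirror-Image Step on a Shared Core

A few compounds are considered here, and "the series" means these few. Any claim that something is new, unique, unknown or untested is made for them only; others in the source may bear on it.

For the measured compounds named here, compound 1 `CN(C)CC[C@@](C)(O)c1ccc2ccccc2c1` gives 205 nM in an assay for displacement of a labelled ligand from Sigma non-opioid intracellular receptor 1 (Cavia porcellus), read by scintillation counting, with a stated time of 120 min (on this read-out lower numbers stand for stronger inhibition and higher numbers for weaker inhibition), the highest of the two numbers measured so far. Compound 2 `COc1ccc2cc([C@](C)(O)CCN(C)C)ccc2c1` gives 51 nM in this assay, and the step of a 4.0-fold lower number from compound 1 to compound 2 (0.60 log units; beyond the scatter) came from a methoxy in place of hydrogen on an aromatic carbon. Compound 3 `CN(C)CC[C@](C)(O)c1ccc2ccccc2c1` differs from compound 1 as follows: the two compounds have the same atoms and bonds and differ only in configuration as drawn: 1 of 1 stereo elements differ; a stereocentre at a saturated chain carbon is drawn R in compound 1 and S in compound 3. Going by the values given here, no measured step changes configuration alone, so the one step seen does not bear on this change. The estimate for compound 3 is 250 nM, within 60 nM to 1200 nM. The expected step of a 1.2-fold higher number from compound 1 to compound 3 (0.09 log units; within the scatter) stays within the scatter.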

Compound 3, inhibition constant: 63 nM
Compound 3: the middle estimate sits 4.0-fold (0.60 log units) above what was measured; the measured number falls inside the stated range.
By their numbers in this assay, from the lowest: compounds 2 and 3 (each within the scatter of the next); then compound 1.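

Configuration at this saturated chain carbon counts in this assay: with atoms and bonds unchanged, drawing the stereocentre S rather than R gives a 3.3-fold lower number from compound 1 to compound 3 (0.51 log units; beyond the scatter). The earlier step concerned only a methoxy in place of hydrogen on an aromatic carbon, so it said nothing about the stereocentre. This gap has a single source: the fact that compounds 1 and 3 differ only in the configuration as drawn

The compounds shown leave open whether methoxy in place of hydrogen would change the number for compound 3 as it did for compound 1. They also leave open what a fluorine on that aromatic carbon, or a longer chain, would do at either configuration.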